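Compound 3 to compound 4: cytotoxicity at the limit

A few compounds are considered here, and "the series" means these few. Any claim that something is new, unique, unknown or untested is made for them only; others in the source may bear on it.

Compound 3 `CC(C)N(CCn1ccc2nc(-c3ccccc3)nc-2c1)C(C)C` reads > 100000 nM in an ADME assay on MDBK cells (Bos taurus) for cytotoxicity (on this read-out higher numbers stand for lower toxicity in this test and lower numbers for higher toxicity in this test), which is a limit of the assay and not a number. Compound 1 `COc1cccc(Cn2ccc3nc(-c4ccccc4)nc-3c2)c1` gives > 100000 nM, also a limit. Compound 2 `c1ccc(-c2nc3cc[nH]cc-3n2)cc1` gives > 100000 nM, again a limit. The measured evidence therefore comes down to the limit of > 100000 nM in this assay, at which 3 of the 3 values shown sit.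

Compound 4 `Clc1ccc(Cn2ccc3nc(-c4ccccc4)nc-3c2)s1` carries 5-chlorothiophen-2-yl in place of (diisopropylamino)methyl on a saturated chain carbon bound to an aromatic nitrogen. Among the compounds with values here, the one measured step at this place is a step that the two limits leave unreadable from compound 1 to compound 3. Within the data shown here, both of its ends are limits, so it offers no size to carry over, and the swap of 3-methoxyphenyl for (diisopropylamino)methyl shows only that neither compound left the limit.

The expected step is an at least 1.2-fold lower number from compound 3 to compound 4 (0.09 log units; that floor lies within the scatter), with nothing beyond the scatter anticipated in either direction, and a reading at the limit is the likeliest outcome. For compound 4 the estimated value is 80000 nM, with an expected range from 25000 nM to 100000 nM.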

Compound 4, half-maximal cytotoxic concentration: > 100000 nM
Compound 4 was reported as a limit; the forecaster's own chance of this, stated with the estimate: 65%; at least 1.2-fold (0.09 log units) between middle value and limit.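

In this assay compound 4 gives > 100000 nM, a limit. Its steps from compound 1, compound 2 and compound 3 cannot be read, with limits at both ends of each. The compounds shown leave open whether any change on the shared core would give a measurable value.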